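This account rests on a few compounds, and the source may have more. Where it says the series, first, only, none or still open, it means among the compounds named here.

Compound 1 has the structure `O=[N+]([O-])c1c(CSc2ccccc2)nc2c(Sc3ccc(Cl)cc3)cc(Cl)cn12`. In an ADME assay on HepG2 cells (Homo sapiens) for cytotoxicity, read by MTT assay, with a stated time of 72 h (a higher number here means that more compound is tolerated, a lower number that less compound is tolerated), compound 1 gives > 15600 nM, which is a limit of the assay rather than a measured number, as the limit of > 15600 nM in this assay, at which 1 of the 2 values shown sits, shows. The second measured compound, compound 2, has the structure `C[S+]([O-])Cc1nc2c(Br)cc(Cl)cn2c1[N+](=O)[O-]`, and in this assay compound 2 gives 51400 nM. Compound 3 has the structure `O=[N+]([O-])c1c(CS(=O)(=O)c2cccnc2)nc2c(Sc3ccc(Cl)cc3)cc(Cl)cn12` and has not yet been tested. It differs from compound 1 in one place: (pyridin-3-yl)sulfonyl in place of phenylsulfanyl on a saturated chain carbon bound to an aromatic carbon. Among the compounds with values here, no measured pair of compounds shows what such a change does in this setting, so there is nothing to point to for its direction. The expected step that the limit leaves unreadable from compound 1 to compound 3 is within the usual scatter, neither upward nor downward beyond it, since compound 1 sits only at the limit of > 15600 nM in this assay, at which 1 of the 2 values shown sits. Compound 3 is therefore expected to give about 30000 nM, with a likely range from 10000 nM to 100000 nM.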

Compound 3, half-maximal cytotoxic concentration: > 31200 nM
Compound 3 gave a limit, no number (the forecaster's own chance of this, stated with the estimate: 50%); at least 1.0-fold (0.01 log units) between middle value and limit.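

Within the data shown here, compound 1 and compound 3 each give only a limit of the assay rather than a number, so no step between them can be read. The compounds shown leave open whether (pyridin-3-yl)sulfonyl in place of phenylsulfanyl shifts the result in this assay, and in which direction.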